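Removing the iodo group from compound 1

The source may report more compounds than this note shows. Statements on the series, on what has been measured and on what is new or still open speak of the compounds shown alone.

These notes follow a small thiosemicarbazone series tested in a functional assay on U-87MG ATCC cells (Homo sapiens) for cytotoxicity, read by MTT assay, with a stated time of 48 h; a lower number here means a stronger inhibitor, a higher number a weaker inhibitor. In this assay, compound 1 (`C/C(=N\NC(=S)Nc1ccccc1I)c1ccccn1`) gives 6.1 nM. Compound 2 (`C/C(=N/NC(=S)Nc1ccccc1F)c1ccccn1`) gives 5 nM. Among the measured compounds shown here, these two values lie within the scatter of each other, so compound 1 cannot be separated from the only other measured compound.

The next compound to be tested is compound 3 (`C/C(=N\NC(=S)Nc1ccccc1)c1ccccn1`). It differs from compound 1 as follows: hydrogen in place of iodo on an aromatic carbon. In words, this is hydrogen in place of iodo on an aromatic carbon. For the measured compounds named here, no step between measured compounds is available to show what such a change does in this assay, so any expectation remains weakly supported. Going by the values given here, the closeness of compound 1 at 6.1 nM and compound 2 at 5 nM is the only guide. A small move towards a higher number, meaning a somewhat weaker inhibitor, is expected, and it may not exceed the scatter. The estimated change is a 1.3-fold higher number from compound 1 to compound 3 (0.12 log units; within the scatter). For compound 3, the expected value is 8 nM, with an estimated range from 2.5 nM to 30 nM.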

Compound 3, half-maximal inhibitory concentration: 1.4 nM
Beside the measured number, compound 3's estimate is 5.7-fold (0.76 log units) above it; the whole stated range lies above it.
By their numbers in this assay, from the lowest: compound 3; then compounds 2 and 1 (each within the scatter of the next).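

Among the compounds shown here, replacing iodo with hydrogen gives, in this assay, a 4.4-fold lower number from compound 1 to compound 3 (0.64 log units; beyond the scatter) and provides the first readable step at this aromatic carbon, ortho to a large group. The closeness of compound 1 and compound 2 had not shown that this position could affect the number, but this single step, beyond the scatter and towards a stronger inhibitor, shows that it can and that the iodo group is not required for the low value of compound 3. Nothing available explains why removing this one heavy atom produces a step of this size.

As far as these compounds go, whether a chloro, methyl or methoxy group, or an amine, on this aromatic carbon would leave the number near that of compound 3 or move it towards that of compound 1 remains open, so it is unclear whether the step is specific to iodo or applies to other groups here. Compound 2 differs from compound 3 in more than one place, including the arrangement about the double bond, so its value cannot serve as a second step at this position.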